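This account rests on a few compounds, and the source may have more. Where it says the series, first, only, none or still open, it means among the compounds named here.

Measured so far:
- compound 1 `COc1cc(OCc2cccc(-c3ccc(C#N)cn3)c2)c2cc(-c3cn4nc(OC)sc4n3)oc2c1` gives 464 ng.h/mL
- compound 2 `CNC(=O)c1ccc(-c2nc(COc3cc(OC)cc4oc(-c5cn6nc(OC)sc6n5)cc34)cs2)cc1` gives 21.9 ng.h/mL

In an ADME assay on the whole organism (Rattus norvegicus), at a dose of 2 mg/kg by the oral route (on this read-out lower numbers stand for lower exposure and higher numbers for higher exposure at the dose given), compound 1 stands highest of the two with 464 ng.h/mL as its number, and compound 2 lies beneath it by a gap beyond the scatter. Compound 3 `COc1ccc(-c2cccc(COc3cc(OC)cc4oc(-c5cn6nc(OC)sc6n5)cc34)c2)nc1` keeps the core of compound 1 and differs in one place: methoxy in place of cyano on an aromatic carbon with methoxy in place of cyano on an aromatic carbon, so 5-cyanopyridin-2-yl becomes 5-methoxypyridin-2-yl. Among the compounds with values here, no measured pair differs in one place only, so this change has no direct precedent. A small downward move within the scatter is expected, and the estimate means a 1.4-fold lower number from compound 1 to compound 3 (0.15 log units; within the scatter) as the expected step. The range is kept wide: compound 2 with 21.9 ng.h/mL as its number shows how far a compound in this series can lie from compound 1. For compound 3 the estimated exposure is 330 ng.h/mL with an expected range of 110 ng.h/mL to 900 ng.h/mL around it.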

Compound 3, area under the concentration-time curve: 1700 ng.h/mL
Estimate against measurement, compound 3: 5.2-fold (0.71 log units) below; the measured number lies above the stated range.
By their numbers in this assay, from the lowest: compound 2; then compound 1; then compound 3.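

In this assay, methoxy in place of cyano on the aromatic carbon two atoms from the ring nitrogen, para to a large group, gives a 3.7-fold higher number from compound 1 to compound 3 (0.56 log units; beyond the scatter). Within the data shown here, this is the first pair that differs in one place only, and it shows that exposure at this position depends on the group carried, even though the two groups match in heavy-atom count and in hydrogen-bond donors and acceptors as counted. Nothing at hand bears on what lies behind this step.

On these data alone, whether the rise is particular to methoxy or would also come with other groups here, such as an amine, a carboxylic acid or a longer alkoxy chain, stays open. Also open, as far as these compounds go, is whether the same change would carry the same step on a compound with a different group elsewhere on the shared core.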